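Compound 1 to compound 4: methoxy to 2-hydroxyethoxy

The source may hold more compounds than are shown below. What is called first, only, known or untested is meant among the compounds shown, and "the series" means these compounds.

Measured in a functional assay on HCT-116 cells (Homo sapiens) for inhibition, read by MTT assay, with a stated time of 72 h; a lower number here means a stronger inhibitor of growth, a higher number a weaker inhibitor of growth:
- compound 1 `COc1ccc(-c2nc3c(N4CCN(Cc5cc(C)on5)CC4)c(Br)cnc3[nH]2)cc1`: 540 nM
- compound 2 `COc1ccc(-c2nc3c(N4CCN(CC5CC5)CC4)c(Br)cnc3[nH]2)cc1`: 830 nM
- compound 3 `CN(C)c1ccc(-c2nc3c(N4CCN(CC(=O)Nc5cccnc5)CC4)c(Br)cnc3[nH]2)cc1`: 1650 nM

Compound 1 has the lowest number of the three only nominally, since the measured step to its nearest neighbour, a 1.5-fold higher number from compound 1 to compound 2 (0.19 log units; within the scatter), does not separate the pair. Its gap to compound 3 does lie beyond the scatter, but compound 3 differs from compound 1 in more than one place, so that gap isolates no single change.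

Compound 4 `Cc1cc(CN2CCN(c3c(Br)cnc4[nH]c(-c5ccc(OCCO)cc5)nc34)CC2)no1` carries one change from compound 1: hydroxymethyl in place of hydrogen on a saturated chain carbon bound to an oxygen on an aromatic ring. This is hydroxymethyl in place of hydrogen on a saturated chain carbon bound to an oxygen on an aromatic ring, so 4-methoxyphenyl becomes 4-(2-hydroxyethoxy)phenyl. For the measured compounds named here, no step has been measured at this place. Going by the values given here, the only single-place step, a 1.5-fold higher number from compound 1 to compound 2 (0.19 log units; within the scatter), concerns a saturated chain carbon bound to an amine nitrogen in a ring, and it gives only weak guidance. No shift beyond the scatter is therefore expected in this assay. The expected step is a 1.1-fold higher number from compound 1 to compound 4 (0.05 log units; within the scatter). For compound 4 the estimated value is 600 nM, with an expected range of 250 nM to 1400 nM.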

Compound 4, concentration for 50% growth inhibition in the HCT-116 assay: 280 nM
The estimate for compound 4 lay 2.1-fold (0.33 log units) above the measured number; measured number inside the range.
By their numbers in the HCT-116 assay, from the lowest: compounds 4, 1, 2 and 3 (each within the scatter of the next, the first and the last beyond it).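

For the compounds shown here, in the HCT-116 assay, the first single-place step at this position, 4-methoxyphenyl to 4-(2-hydroxyethoxy)phenyl, gives a 1.9-fold lower number from compound 1 to compound 4 (0.29 log units; within the scatter), so the pair is not separated and this place carries the 2-hydroxyethoxy chain with no shift beyond the scatter. In a physicochemical assay for solubility (a higher number here means a more soluble compound, a lower number a less soluble compound), compound 1 gives < 10 ug/mL, which is a limit of the assay and not a number. In the physicochemical assay, compound 4 gives 10 ug/mL, and the step for this pair cannot be read: the limit of < 10 ug/mL in the physicochemical assay, at which 1 of the 2 values shown sits.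

The compounds shown leave open whether an amine such as 2-aminoethoxy, a carboxylic acid such as carboxymethoxy or a longer chain such as 3-hydroxypropoxy would read the same way at this place in the HCT-116 assay. They also leave open whether 2-hydroxyethoxy gives a similar step with the cyclopropyl of compound 2, and how far apart compound 1 and compound 4 sit in the physicochemical assay.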